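A few compounds are considered here, and "the series" means these few. Any claim that something is new, unique, unknown or untested is made for them only; others in the source may bear on it.

Measured compounds:
compound 1 `COc1cc(-c2ccnc3cc(-c4ccc(C)cc4)nn23)cc(OC)c1OC` — in a functional assay on MCF7 cells (Homo sapiens) for inhibition, read by CCK-8 assay, with a stated time of 48 h (a lower number here means a stronger inhibitor, a higher number a weaker inhibitor), compound 1 gives 47 nM
compound 2 `COc1cc(-c2ccnc3cc(-c4ccc5cc[nH]c5c4)nn23)cc(OC)c1OC` — in this assay compound 2 gives 23 nM
compound 3 `COc1ccc(-c2cc3nccc(-c4cc(OC)c(OC)c(OC)c4)n3n2)cc1[N+](=O)[O-]` — in this assay compound 3 gives only a limit, > 10000 nM

Among the compounds with values here, the one step between compounds that differ in a single place is a 2.0-fold lower number from compound 1 to compound 2 (0.31 log units; beyond the scatter), an exchange of the aryl group on the shared core. Compound 3 stands apart from both: in this assay compound 3 reaches only (the limit of > 10000 nM in this assay, at which 1 of the 3 values shown sits), so no number is known for it and its distance from compound 1 or compound 2 cannot be stated.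

Compound 4 `COc1ccc(-c2cc3nccc(-c4cc(OC)c(OC)c(OC)c4)n3n2)cc1F` differs from compound 3 by fluoro in place of nitro on an aromatic carbon. Within the data shown here, no measured step covers this exchange; the step from compound 1 to compound 2 concerns a different part of the molecule, so it offers no guide to the size or direction of the change in this assay. Only the structural change itself and the limit of compound 3 remain. On that basis compound 4 is expected to give 1000 nM, with a range from 80 nM to 10000 nM. That estimate means an expected at least 10-fold lower number from compound 3 to compound 4 (1.00 log units; beyond the scatter), and a limit rather than a number remains a real possibility.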

Compound 4, half-maximal inhibitory concentration: 183 nM
Compound 4: middle estimate off by 5.5-fold (0.74 log units), on the high side; measured number inside the range.
By their numbers in this assay, from the lowest: compound 2; then compound 1; then compound 4. At a limit, above all of these: compound 3.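

In this assay, the aromatic carbon ortho to a methoxy group turns out to decide much of the activity, with an at least 54-fold lower number from compound 3 to compound 4 (1.73 log units; beyond the scatter), so exchanging nitro for fluoro at this single place brings the aryl group back into a measurable range. The value of compound 3 is a limit and not a number: the limit of > 10000 nM in this assay, at which 1 of the 4 values shown sits. The 3-fluoro-4-methoxyphenyl group still falls behind the other aryl groups on the shared core, with an 8.0-fold higher number from compound 2 to compound 4 (0.90 log units; beyond the scatter) and a 3.9-fold higher number from compound 1 to compound 4 (0.59 log units; beyond the scatter).

As far as these compounds go, it remains open whether other groups at this place, such as an amine, a hydroxyl or a nitrile, would land nearer compound 4 or compound 3. From the compounds shown here alone, whether fluoro itself matters, compared with a plain hydrogen at the same carbon, also stays open.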